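A few compounds are considered here, and "the series" means these few. Any claim that something is new, unique, unknown or untested is made for them only; others in the source may bear on it.

Among the measured compounds shown here, in an ADME assay on HUVEC cells (Homo sapiens) for inhibition, read by MTT assay, with a stated time of 48 h (a higher number here means a weaker inhibitor, a lower number a stronger inhibitor), compound 3 `COc1cc(/C=N/Nc2nc(-c3ccc(F)c(F)c3)cs2)c(Br)c(Br)c1OC` gives 54700 nM, the only number among the three values shown. Compound 1 `COc1cc(/C=N/Nc2nc(-c3ccc(Br)cc3)cs2)cc(Br)c1OC` stops at the assay limit, > 100000 nM. Compound 2 `COc1cc(/C=N/Nc2nc(-c3ccc(F)c(F)c3)cs2)cc(Br)c1OC` likewise stops at the limit, > 100000 nM. Beyond the single number of compound 3 stands (the limit of > 100000 nM in this assay, at which 2 of the 3 values shown sit). Compound 4 `COc1cc(/C=N/Nc2nc(-c3cccc(Br)c3)cs2)c(Br)c(Br)c1OC` differs from compound 3 by 3-bromophenyl in place of 3,4-difluorophenyl on an aromatic carbon. The earlier exchange of the aryl group gave a step that the two limits leave unreadable from compound 1 to compound 2, which leaves no readable guide for such a change; the added bromo gave an at least 1.8-fold lower number from compound 2 to compound 3 (0.26 log units; that floor lies within the scatter), which does not touch the aryl group. Compound 4 is therefore expected to stay close, with an estimated step of a 1.1-fold lower number from compound 3 to compound 4 (0.04 log units; within the scatter). In this assay compound 4 is estimated at 50000 nM, with a range from 20000 nM to 150000 nM.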

Compound 4, half-maximal inhibitory concentration: > 100000 nM
Compound 4 gave a limit, no number (the forecaster's own chance of this, stated with the estimate: 40%); middle value at least 2.0-fold (0.30 log units) from the limit.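

In this assay, 3-bromophenyl in place of 3,4-difluorophenyl on this aromatic carbon gives an at least 1.8-fold higher number from compound 3 to compound 4 (0.26 log units; that floor lies within the scatter), so an aryl exchange at this position now has a readable floor, which the earlier one lacked. That floor alone does not establish a real change. Compound 4 is a limit of the assay, not a number, and joins the other limit values: the limit of > 100000 nM in this assay, at which 3 of the 4 values shown sit.

On these data alone, how far the number lies from that of compound 3 stays open, since the limit hides the true size of the step. Also open, as far as these compounds go, is how an amine or a carboxylic acid in place of the bromo on the 3-bromophenyl group would read.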